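A few compounds are considered here, and "the series" means these few. Any claim that something is new, unique, unknown or untested is made for them only; others in the source may bear on it.

Compound 1 `CCNCC(=O)Nc1cc(OC)ccc1C(=O)c1ccc(OC)c2c1OC(C)(C)C=C2`, compound 2 `COc1ccc(C(=O)c2ccc(OC)c3c2OC(C)(C)C=C3)c(NC(=O)CN(C)C)c1` and compound 3 `CCNCC(=O)Nc1cc(OC)ccc1C(=O)c1cc(OC)c(OC)c(OC)c1` were all tested in a functional assay on A549 cells (Homo sapiens) for antiproliferative activity, read by MTT assay, with a stated time of 48 h; on this read-out lower numbers stand for stronger inhibition and higher numbers for weaker inhibition. In this assay compound 1 gives 1050 nM, compound 2 gives 890 nM and compound 3 gives 750 nM.

Compound 1 and compound 2 share one core and differ in a single place: dimethylamino in place of ethylamino on a saturated chain carbon bound to a carbonyl carbon. This change gives a 1.2-fold lower number from compound 1 to compound 2 (0.07 log units; within the scatter). Compound 3 carries a different core; the difference between the two cores is not broken down here. Compound 4 `COc1ccc(C(=O)c2cc(OC)c(OC)c(OC)c2)c(NC(=O)CN(C)C)c1` is not yet measured; it stands to compound 3 exactly as compound 2 stands to compound 1, the change being (dimethylamino in place of ethylamino on a saturated chain carbon bound to a carbonyl carbon). The place of the change is the same in both pairs, so the two changes are the same change, made twice among the compounds shown.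

For the measured compounds named here, the single measured instance of this change moved the number by an amount within the usual scatter of repeated measurements, so on this assay the change looks close to neutral; with one example only, nothing beyond that can be claimed. For compound 4 the expected step is a 1.2-fold lower number from compound 3 to compound 4 (0.06 log units; within the scatter), and this expectation rests on compound 1 moving to compound 2 by a 1.2-fold lower number from compound 1 to compound 2 (0.07 log units; within the scatter). Compound 4 is therefore expected to give about 650 nM in this assay, with the value estimated to fall between 350 nM and 1200 nM.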

Compound 4, half-maximal inhibitory concentration: 590 nM
For compound 4 the middle estimate is 1.1-fold (0.04 log units) above the measured one, and the stated range covers the measured number.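

In this assay, putting dimethylamino in place of ethylamino on the core of compound 3 gives a 1.3-fold lower number from compound 3 to compound 4 (0.10 log units; within the scatter), so on this second core too the change stays inside what repeated measurements would be expected to show. Set side by side, the two instances of the change agree, and carrying it from one core to the other leaves its outcome in this read-out unaltered as far as can be seen: the same change on two cores in this assay, a 1.2-fold lower number (0.07 log units; within the scatter) from compound 1 to compound 2 and a 1.3-fold lower number (0.10 log units; within the scatter) from compound 3 to compound 4, 1.1-fold (0.03 log units) apart, within the scatter of two such steps. For the compounds shown here, this shows that the change looks close to neutral on both cores, but with only two pairs, and both steps within the scatter, it establishes neither a true direction nor a true size for the change, and it says nothing about how the change would behave on any third core or in any other read-out.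

The compounds shown leave open whether the chain carbon tolerates amines of a different kind, such as a primary amine, pyrrolidine, piperidine or morpholine, as readily as it tolerates ethylamino and dimethylamino. They also leave open what a longer chain between the carbonyl and the amine would do, and whether a carboxylic acid in place of the amine would keep the numbers in the same range on either core.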